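The compounds below may be only part of what the source reports. "The series", "measured", "known", "first", "only" and "open" are said of these compounds alone.

In a functional assay on HepG2 cells (Homo sapiens) for inhibition, read by MTT assay, with a stated time of 48 h (on this read-out lower numbers stand for stronger inhibition and higher numbers for weaker inhibition), three compounds have been measured so far:

Compound 1, `O=C(Nc1cnn(-c2ccccc2)c1)c1cccc(NS(=O)(=O)c2ccccc2)c1`, gives 10100 nM.
Compound 2, `Cc1ccc(-n2cc(NC(=O)c3cccc(NS(=O)(=O)c4ccccc4)c3)cn2)cc1`, gives 6050 nM.
Compound 3, `O=C(Nc1cnn(-c2ccccc2)c1)c1ccc(NS(=O)(=O)c2ccccc2)cc1`, gives 21500 nM.

Compound 2 differs from compound 1 in one place only, (methyl in place of hydrogen on an aromatic carbon), and this gave a 1.7-fold lower number from compound 1 to compound 2 (0.22 log units; within the scatter). Compound 3 is built from the same atoms as compound 1, joined differently; the difference between the two cores is not broken down here. Of the three numbers, that of compound 3 is the highest, so compound 3 is the weakest inhibitor of the three in this assay.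

Compound 4, `Cc1ccc(-n2cc(NC(=O)c3ccc(NS(=O)(=O)c4ccccc4)cc3)cn2)cc1`, has not yet been measured. It stands to compound 3 as compound 2 stands to compound 1: methyl in place of hydrogen on an aromatic carbon, the same change at the same kind of place. For the measured compounds named here, the only precedent for this change is a 1.7-fold lower number from compound 1 to compound 2 (0.22 log units; within the scatter), which stayed within the scatter, and a step of about the same size is expected from compound 3 to compound 4. Compound 4 is therefore expected to give about 13000 nM in this assay, most likely between 5500 nM and 30000 nM. That estimate means an expected step of a 1.7-fold lower number from compound 3 to compound 4 (0.22 log units; within the scatter), small enough to lie within the usual scatter.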

Compound 4, half-maximal inhibitory concentration: 18100 nM
The estimate for compound 4 lay 1.4-fold (0.14 log units) below the measured number; the range from low to high includes it.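

In this assay, methyl in place of hydrogen on an aromatic carbon gave a 1.2-fold lower number from compound 3 to compound 4 (0.07 log units; within the scatter), so on the second core too the step stays within the usual scatter. Set beside the earlier step, the two do not differ: the same change on two cores in this assay, a 1.7-fold lower number (0.22 log units; within the scatter) from compound 1 to compound 2 and a 1.2-fold lower number (0.07 log units; within the scatter) from compound 3 to compound 4, 1.4-fold (0.15 log units) apart, within the scatter of two such steps. This shows that the change from phenyl to 4-methylphenyl carried across these two cores as a step too small to read on either, but it does not show that the methyl matters for inhibition on either core, and two pairs say nothing about any other core.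

The compounds shown leave open whether another group in the place of that methyl, such as an amine, a carboxylic acid or a longer chain, would give a step beyond the scatter. They also leave open whether such a group would give steps of like size on both cores.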